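Swapping the Para Halogen on the Aryl Ring

The source may report more compounds than this note shows. Statements on the series, on what has been measured and on what is new or still open speak of the compounds shown alone.

Compound 1 `CO[C@@]12CCN(C)C[C@H]1[C@H](c1ccccc1)C(C#N)=C(N)O2` gives 19800 nM in a functional assay on trachea (Cavia porcellus); a lower number here means a stronger inhibitor, a higher number a weaker inhibitor.
Compound 2 `CO[C@@]12CCN(C)C[C@H]1[C@H](c1ccc(Br)cc1)C(C#N)=C(N)O2` gives 7900 nM in this assay.
Compound 3 `CCN1CC[C@@]2(OC)OC(N)=C(C#N)[C@@H](c3ccc(Br)cc3)[C@@H]2C1` gives 13200 nM in this assay.

Among these three numbers, compound 2 has the lowest. Its gap to compound 1 is real: a 2.5-fold lower number from compound 1 to compound 2 (0.40 log units; beyond the scatter). Its gap to compound 3 is not: a 1.7-fold higher number from compound 2 to compound 3 (0.22 log units; within the scatter), so compound 2 and compound 3 cannot be told apart in this assay.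

Compound 4 `CO[C@@]12CCN(C)C[C@H]1[C@H](c1ccc(Cl)cc1)C(C#N)=C(N)O2` differs from compound 2 in one place: chloro in place of bromo on an aromatic carbon. Among the compounds with values here, no measured pair shows a chloro replacing a bromo, so the only step that bears on this change is the one that introduced the bromo, a 2.5-fold lower number from compound 1 to compound 2 (0.40 log units; beyond the scatter), which was modest. A chloro at the same place is expected to behave much like the bromo, so the step is expected to be small and within the scatter, if anything towards a slightly higher number, that is a slightly weaker inhibitor: a 1.3-fold higher number from compound 2 to compound 4 (0.10 log units; within the scatter).

Compound 4 is therefore expected to give about 10000 nM in this assay, with a likely range from 5000 nM to 20000 nM.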

Compound 4, half-maximal inhibitory concentration: 10500 nM
Estimate against measurement, compound 4: 1.1-fold (0.02 log units) below, within the range that was stated.
By their numbers in this assay, from the lowest: compounds 2, 4, 3 and 1 (each within the scatter of the next, the first and the last beyond it).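

In this assay, exchanging one halogen directly for the other at this aromatic carbon gives a 1.3-fold higher number from compound 2 to compound 4 (0.12 log units; within the scatter), so at this place bromo and chloro cannot be told apart. Within the data shown here, the comparison with hydrogen is less clear-cut: chloro gives a 1.9-fold lower number from compound 1 to compound 4 (0.28 log units; within the scatter), which lies within the scatter, while bromo gives a 2.5-fold lower number from compound 1 to compound 2 (0.40 log units; beyond the scatter), which lies just beyond it, so compound 4 can be separated from neither compound 1 nor compound 2, and the case for a halogen at this place improving on hydrogen rests on the single bromo step. No supporting measurement is available to explain these numbers, so the result describes what happens at this position but not the reason for it.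

The compounds shown leave open whether a fluoro, a methoxy, an amine or a carboxylic acid at this same place would give a number close to those of the two halogens or one clearly different from them. They also leave open whether chloro would still match bromo in the core of compound 3, where the group on the ring nitrogen is longer.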